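This account rests on a few compounds, and the source may have more. Where it says the series, first, only, none or still open, it means among the compounds named here.

In an ADME assay on J774.1 cells (Mus musculus) for cytotoxicity, read by resazurin assay, with a stated time of 48 h (a higher number here means a weaker inhibitor, a lower number a stronger inhibitor), compound 1 `CCCCn1cc(C(=O)O)c(=O)c2cc(F)c(Cl)cc21` gives > 100000 nM, which is a limit of the assay and not a number. Compound 3 `CCCCn1cc(C(=O)NCc2ccccc2)c(=O)c2cc(F)c(N(C)C)cc21` gives > 100000 nM, also a limit. Compound 1 thus stands at the limit of > 100000 nM in this assay, at which 2 of the 3 values shown sit.

Compound 4 `CCCCn1cc(C(=O)O)c(=O)c2cc(F)c(N3CCC(C(N)=O)CC3)cc21` has 4-carbamoylpiperidin-1-yl in place of chloro on an aromatic carbon. Going by the values given here, no measured pair isolates this change. Among the compounds with values here, the only guide is compound 2 `CCCn1cc(C(=O)NCc2ccccc2)c(=O)c2cc(F)c(N3CCC(C(N)=O)CC3)cc21`, which carries the same group but also differs elsewhere, and gives 43700 nM. A small step toward a lower number in this assay is therefore expected, and compound 4 may well stay at the limit. The estimated change is an at least 1.2-fold lower number from compound 1 to compound 4 (0.09 log units; that floor lies within the scatter). For compound 4 the expected value is 80000 nM, with an estimated range of 35000 nM to 100000 nM.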

Compound 4, half-maximal inhibitory concentration: > 100000 nM
Compound 4 gave a limit, no number; the forecaster's own chance of this, stated with the estimate: 60%; middle value at least 1.2-fold (0.09 log units) from the limit.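

Compound 1 and compound 4 both give a limit and not a number, so no step can be read between them: the limit of > 100000 nM in this assay, at which 3 of the 4 values shown sit. From the compounds shown here alone, whether 4-carbamoylpiperidin-1-yl in place of chloro changes cytotoxicity at all stays open.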